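Dechlorination of the anilino ring in compound 2

The source may hold more compounds than are shown below. What is called first, only, known or untested is meant among the compounds shown, and "the series" means these compounds.

In a functional assay on HCT-116 cells (Homo sapiens) for antiproliferative activity, read by CCK-8 assay, with a stated time of 72 h, tested at 8 uM (a higher number here means a stronger effect of the compound at the concentration tested, a lower number a weaker effect), compound 2 `Nc1ccccc1NC(=O)/C=C/c1ccc(Cn2cnc3c(Nc4cccc(Cl)c4)nc(Cl)nc32)cc1` gives 15.8%, the lowest of the three numbers in hand. Compound 1 `CC(C)n1cnc2c(Nc3ccccc3)nc(NCOCc3ccc(C(=O)Nc4ccccc4N)cc3)nc21` gives 18.8%, which lies within the scatter of compound 2. Going by the values given here, compound 3 `Nc1ccccc1NC(=O)c1ccc(Cn2cnc3c(Nc4cccc(Cl)c4)nc(Cl)nc32)cc1` gives 78.4%; the step of a number 62.6 percentage points higher from compound 2 to compound 3 (beyond the scatter) is the only measured step in the set, and it concerns the carbamoyl linker on the benzyl ring, not the anilino ring.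

Compound 4 `Nc1ccccc1NC(=O)/C=C/c1ccc(Cn2cnc3c(Nc4ccccc4)nc(Cl)nc32)cc1` differs from compound 2 in one place: hydrogen in place of chloro on an aromatic carbon. Among the compounds with values here, no measured pair varies this position while holding the rest constant, so the single step in hand, a number 62.6 percentage points higher from compound 2 to compound 3 (beyond the scatter), does not bear on the present change, and the expectation rests on compound 2 alone. The change is small, a single chlorine leaving with a hydrogen entering, and nothing in the data points either way. The step of a number 2.2 percentage points higher from compound 2 to compound 4 (within the scatter) is therefore expected to stay within the scatter. Within the data shown here, compound 4 is accordingly estimated at 18%, with a range of 4% to 40%, the width of the range reflecting that no measured step informs this particular change.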

Compound 4, a percentage reported as inhibition, at one concentration (the size of the read-out at that concentration, not a potency): 30.9%
Compound 4: middle estimate off by 12.9 percentage points, on the low side, and the stated range covers the measured number.
By their numbers in this assay, from the lowest: compounds 2 and 1 (each within the scatter of the next); then compound 4; then compound 3.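

Going by these compounds alone, this is the first measured change on the anilino ring, and in this assay the move from 3-chlorophenyl to phenyl reads as a number 15.1 percentage points higher from compound 2 to compound 4 (beyond the scatter) and is modest in size. The earlier step of a number 62.6 percentage points higher from compound 2 to compound 3 (beyond the scatter) concerned only the linker on the benzyl ring, so the series now shows that the anilino ring also affects this read-out, though here with the ethenyl linker kept in place and at a single concentration, which gives the size of the effect there and not a potency. No measurement at hand bears on what lies behind the step, so it stands as an observation on this one pair.

Going by these compounds, it remains open whether hydrogen in place of chloro moves the number in the same direction on the shorter carbamoyl linker of compound 3, which carries the chloro group and already reads much higher. Also open, on these data alone, is how a fluoro, methoxy or amino group on this same aromatic carbon would compare with chloro and hydrogen.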